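Fluoro to methoxy on the phenyl group: expected tolerance

A few compounds are considered here, and "the series" means these few. Any claim that something is new, unique, unknown or untested is made for them only; others in the source may bear on it.

In an ADME assay on RAW264.7 cells (Mus musculus) for cytotoxicity, read by MTT assay, with a stated time of 48 h (a higher number here means that more compound is tolerated, a lower number that less compound is tolerated), compound 2 `CC(=O)OC[C@H]1O[C@H](OC[C@@H](Cn2cc(CN(c3nc(-c4ccc(F)cc4)no3)C3CCCCC3)nn2)OC(C)=O)C=C[C@@H]1OC(C)=O` gives 31.5 ug/mL, the second highest of the three numbers gathered so far. Compound 1 `CC(=O)OC[C@H]1O[C@H](OC[C@@H](Cn2cc(CN(c3nc(-c4ccc(Cl)cc4)no3)C3CCCCC3)nn2)OC(C)=O)C=C[C@@H]1OC(C)=O` gives 35.5 ug/mL, and the step of a 1.1-fold lower number from compound 1 to compound 2 (0.05 log units; within the scatter) stays within the scatter. Among the measured compounds shown here, compound 3 `C#CCN(c1nc(-c2ccc(Cl)cc2)no1)C1CCCCC1` gives 15.1 ug/mL; no single-site step links compound 3 to compound 2, so the two values are simply noted side by side, with compound 3 the lower one beyond the scatter.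

Compound 4 `COc1ccc(-c2noc(N(Cc3cn(C[C@H](CO[C@@H]4C=C[C@H](OC(C)=O)[C@@H](COC(C)=O)O4)OC(C)=O)nn3)C3CCCCC3)n2)cc1` has not yet been measured. It differs from compound 2 by methoxy in place of fluoro on an aromatic carbon. For the measured compounds named here, the only measured step at the same aromatic carbon is the one from compound 1 to compound 2, a chloro to fluoro exchange that produced no movement beyond the scatter. Nothing measured here covers a methoxy at this site, so the expectation rests on that single step: the move in this assay is expected to be small, a 1.1-fold lower number from compound 2 to compound 4 (0.02 log units; within the scatter), in no clear direction. For compound 4 the estimated value is 30 ug/mL, with an expected range of 15 ug/mL to 60 ug/mL.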

Compound 4, half-maximal cytotoxic concentration: 86.3 ug/mL
The estimate for compound 4 lay 2.9-fold (0.46 log units) below the measured number, and the stated range ends below it.
By their numbers in this assay, from the lowest: compound 3; then compounds 2 and 1 (each within the scatter of the next); then compound 4.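

At this aromatic carbon the exchange of chloro for fluoro had moved nothing beyond the scatter in this assay, but methoxy gives a 2.7-fold higher number from compound 2 to compound 4 (0.44 log units; beyond the scatter) and, set against chloro, a 2.4-fold higher number from compound 1 to compound 4 (0.39 log units; beyond the scatter) as well. The position is therefore not indifferent to its substituent: the two halogens stay within the scatter of each other, while the 4-methoxyphenyl compound separates from both towards more compound tolerated. Nothing available here accounts for this separation.

The compounds shown leave open whether the higher number belongs to methoxy alone or extends to other groups on this carbon, such as a hydroxyl, an ethoxy or an amine. They also leave open whether the same change would hold in the background of compound 3.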